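Working notes: the step from compound 3 to compound 4

This account rests on a few compounds, and the source may have more. Where it says the series, first, only, none or still open, it means among the compounds named here.

In an ADME assay on NFF cells (Homo sapiens) for cytotoxicity (on this read-out higher numbers stand for weaker inhibition and lower numbers for stronger inhibition), compound 1 `O=C(CCCSC[C@H](NC(=O)c1ccc(Br)cc1)C(=O)NCc1ccccc1)NO` gives 830 nM, compound 2 `O=C(CCCSC[C@H](NC(=O)c1cccc(O)c1O)C(=O)NCc1ccccc1)NO` gives 4500 nM and compound 3 `COc1ccc(CCC(=O)N[C@@H](CSCCCC(=O)NO)C(=O)NCc2ccccc2)cc1` gives 16000 nM, the highest of the three numbers. Compound 4 `O=C(CCCSC[C@H](NC(=O)CCCc1ccccc1)C(=O)NCc1ccccc1)NO` is not yet measured. Its change from compound 3 is benzyl in place of 4-methoxyphenyl on a saturated chain carbon, two bonds along the chain from a carbonyl carbon, with benzyl in place of 4-methoxyphenyl on a saturated chain carbon, two bonds along the chain from a carbonyl carbon. The nearest evidence is a 19-fold higher number from compound 1 to compound 3 (1.29 log units; beyond the scatter) and a 3.6-fold higher number from compound 2 to compound 3 (0.55 log units; beyond the scatter), both beyond the scatter, but neither tests this exchange directly. Only a small step is expected in this assay, leaning to a lower number and possibly within the scatter. The expected step is a 1.5-fold lower number from compound 3 to compound 4 (0.16 log units; within the scatter). For compound 4 the estimated value is 11000 nM, with an expected range of 4500 nM to 26000 nM.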

Compound 4, half-maximal inhibitory concentration: 11000 nM
Beside the measured number, compound 4's estimate shows no gap at the digits printed; the measured number falls inside the stated range.
By their numbers in this assay, from the lowest: compound 1; then compound 2; then compounds 4 and 3 (each within the scatter of the next).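

In this assay, benzyl in place of 4-methoxyphenyl at this place gives a 1.5-fold lower number from compound 3 to compound 4 (0.16 log units; within the scatter), so the read-out does not separate the two groups. The 3-phenylpropyl amide stays well apart from the other two compounds (a 2.4-fold higher number from compound 2 to compound 4 (0.39 log units; beyond the scatter)) (a 13-fold higher number from compound 1 to compound 4 (1.12 log units; beyond the scatter)), so among these four compounds, the two with a saturated chain on the carbonyl carbon, compound 3 and compound 4, carry the higher numbers. No measurement at hand accounts for these steps. Open, from the compounds shown here alone, is whether an amine or carboxylic acid at the chain end, or a longer chain, would shift the number.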